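Swapping the halogenated aryl arm on a shared core

This account rests on a few compounds, and the source may have more. Where it says the series, first, only, none or still open, it means among the compounds named here.

Measured so far:
compound 1 `C=CCn1c(=O)/c(=C\c2cc(F)ccc2C)[nH]c(=O)/c1=C\c1ccccc1OC` — 3800 nM
compound 2 `COc1ccccc1/C=c1\c(=O)[nH]/c(=C/c2ccccc2Cl)c(=O)n1C` — "not determined" (no result reported)
compound 3 `C=CCn1c(=O)/c(=C\c2cccc(Br)c2)[nH]c(=O)/c1=C\c1cccc(Br)c1` — "not active" (no number reported)

In a functional assay on MOLT-4 cells (Homo sapiens) for cytotoxicity, read by CCK-8 assay, with a stated time of 72 h (on this read-out higher numbers stand for weaker inhibition and lower numbers for stronger inhibition), compound 1 gives 3800 nM. Among the measured compounds shown here, it is the only compound here with a number; compound 2 carries no result and compound 3 was reported as showing no activity, so compound 1 stands alone as the reference point. Compound 4 `C=CCn1c(=O)/c(=C\c2ccc(Cl)c(Cl)c2)[nH]c(=O)/c1=C\c1ccccc1OC` is not yet measured. It differs from compound 1 by 3,4-dichlorophenyl in place of 5-fluoro-2-methylphenyl on a double-bonded chain carbon bound to an aromatic carbon. For the measured compounds named here, with no measured pair showing this kind of exchange, there is no basis for a large shift. In this assay the expected step is a modest 1.3-fold higher number from compound 1 to compound 4 (0.12 log units; within the scatter). Compound 4 is therefore estimated at 5000 nM, with a plausible range from 1500 nM to 20000 nM.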

Compound 4, half-maximal inhibitory concentration: "not active" (no number reported)
No number was reported for compound 4; no gap can be computed for the estimate.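

Among the compounds shown here, compound 4 was reported as not active and carries no number, so no step from compound 1 can be read, and no other data bear on this result. The compounds shown leave open how far the 3,4-dichlorophenyl and 5-fluoro-2-methylphenyl arms really differ on the shared core.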